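Carboxy to carbamoyl: notes on compound 4

The source may hold more compounds than are shown below. What is called first, only, known or untested is meant among the compounds shown, and "the series" means these compounds.

Compound 1 `COc1cccnc1Nc1cc2[nH]c(-c3cccc(C(F)(F)F)c3)nc2cn1` gives 116000 nM in a physicochemical assay for solubility, using the shake flask method, measured as kinetic solubility, with a stated time of 20 h, at pH 2 (a higher number here means a more soluble compound, a lower number a less soluble compound), and compound 2 `FC(F)(F)c1cccc(-c2nc3cnc(Nc4cnccn4)cc3[nH]2)c1` gives 155000 nM; the step of a 1.3-fold higher number from compound 1 to compound 2 (0.13 log units; within the scatter) sits within the scatter. Compound 3 `O=C(O)c1ccc(Nc2cc3[nH]c(-c4cccc(C(F)(F)F)c4)nc3cn2)nc1` shows only < 5000 nM in this assay, which is a limit and not a number. The steps of an at least 23-fold lower number from compound 1 to compound 3 (1.36 log units; beyond the scatter) and an at least 31-fold lower number from compound 2 to compound 3 (1.49 log units; beyond the scatter) are both large and both end at the limit of < 5000 nM in this assay, at which 1 of the 3 values shown sits. Compound 4 `NC(=O)c1ccc(Nc2cc3[nH]c(-c4cccc(C(F)(F)F)c4)nc3cn2)nc1` differs from compound 3 by amino in place of hydroxy on a carbonyl carbon. Among the compounds with values here, none of the measured steps covers this change: the two large steps each exchange the whole ring on the nitrogen, whereas here the ring stays and only the carboxy becomes carbamoyl. The expected step is therefore modest, an at least 2.0-fold higher number from compound 3 to compound 4 (0.30 log units; that floor lies within the scatter), with a real chance of another limit. Compound 4 is estimated near 10000 nM, within 2000 nM to 60000 nM.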

Compound 4, solubility: < 5000 nM
Compound 4: a limit, no number (the forecaster's own chance of this, stated with the estimate: 35%); at least 2.0-fold (0.30 log units) between middle value and limit.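

With the ring kept, the carbamoyl compound stands as far from the two open-valued compounds as the carboxy compound does, so the large gap in this assay is not peculiar to carboxy (an at least 31-fold lower number from compound 2 to compound 4 (1.49 log units; beyond the scatter); an at least 23-fold lower number from compound 1 to compound 4 (1.36 log units; beyond the scatter)). The step between compound 3 and compound 4 cannot be read. Both 5-substituted pyridin-2-yl compounds now end at a limit: the limit of < 5000 nM in this assay, at which 2 of the 4 values shown sit.

Going by these compounds, how far compound 3 and compound 4 lie from that limit stays open. Also open, on these data alone, is whether an amine or a nitrile in place of carbamoyl would give a number.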